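This account rests on a few compounds, and the source may have more. Where it says the series, first, only, none or still open, it means among the compounds named here.

Measured so far in a functional assay on HCC827 cells (Homo sapiens) for inhibition, read by MTT assay, with a stated time of 48 h, tested at 10 uM; a lower number here means less inhibition, a higher number more inhibition at the concentration tested (going by the name of the read-out):
compound 1 `COc1cc(NC(=O)Nc2cc(Nc3ccc(OC)c(C)c3)ncn2)cc(OC)c1` — 48.3%
compound 2 `COc1ccc(F)cc1Nc1cc(NC(=O)Nc2c(Cl)cccc2Cl)ncn1` — 78%
compound 3 `COc1cc(NC(=O)Nc2cc(Nc3cc(C)cc(F)c3)ncn2)cc(OC)c1` — 62.1%

Compound 3 stands second of the three numbers in this assay. Its nearest neighbour is compound 1, which reads a number 13.8 percentage points higher from compound 1 to compound 3 (beyond the scatter); the furthest is compound 2, whose value sits higher than that of compound 3 by a margin beyond the scatter. Compound 2 differs from compound 3 in more than one place, so its number only shows that a higher value is reachable within the series.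

The next compound, compound 4 `COc1cc(NC(=O)Nc2cc(Nc3cc(I)ccc3OC)ncn2)cc(OC)c1`, is not yet measured. Relative to compound 3 the change is 5-iodo-2-methoxyphenyl in place of 3-fluoro-5-methylphenyl on a nitrogen on an aromatic ring. Among the compounds with values here, the only measured step that touches the same position is the one from compound 1 to compound 3, a number 13.8 percentage points higher from compound 1 to compound 3 (beyond the scatter), a modest move for an exchange of the aryl group on that nitrogen. That single step gives little guidance on the direction for the new aryl group; exchanges at this site have so far moved the number modestly, in either direction once compound 2 is taken into view. The expected step is therefore small, a number 4.1 percentage points lower from compound 3 to compound 4 (within the scatter), with the direction uncertain.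

Compound 4 is estimated at 58% in this assay, within a range of 40% to 78%.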

Compound 4, a percentage reported as inhibition, at one concentration (the size of the read-out at that concentration, not a potency): 71%
Compound 4: the middle estimate sits 13 percentage points below what was measured, within the range that was stated.
By their numbers in this assay, from the lowest: compound 1; then compounds 3, 4 and 2 (each within the scatter of the next, the first and the last beyond it).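

In this assay the aryl group on a nitrogen on an aromatic ring now has three members on the shared core, and the step of a number 8.9 percentage points higher from compound 3 to compound 4 (within the scatter) shows that 5-iodo-2-methoxyphenyl and 3-fluoro-5-methylphenyl cannot be told apart here, although the entering group has a hydrogen-bond acceptor and the leaving group has none. The further step a number 22.7 percentage points higher from compound 1 to compound 4 (beyond the scatter) means that 4-methoxy-3-methylphenyl alone stands apart among these three groups, with the other two both beyond the scatter from it. A methoxy group occurs on the aryl groups of both compound 1 and compound 4, whose numbers lie beyond the scatter of each other, so the presence of a methoxy group alone does not set the number in this small set.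

No measurement at hand accounts for these differences.

From the compounds shown here alone, the separate contributions of the iodine and the methoxy group within 5-iodo-2-methoxyphenyl remain open. Going by these compounds, it is also open whether an aryl group carrying a piperazine or a carboxylic acid would stay level with compound 3 and compound 4 or fall towards compound 1.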